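The compounds below may be only part of what the source reports. "The series", "measured", "known", "first", "only" and "open" are said of these compounds alone.

Measured so far in an assay on CHO cells for displacement of a labelled ligand from adenosine receptor A1 (Homo sapiens), read by scintillation counting, with a stated time of 120 min, tested at 10 uM; a lower number here means less inhibition, a higher number more inhibition at the concentration tested (going by the name of the read-out):

- compound 1 `Nc1scc(CN2CCN(c3cc(Cl)cc(Cl)c3)CC2)c1C(=O)c1ccc(Cl)cc1`: 1%
- compound 2 `Nc1scc(CN2CCN(c3ccc(OC(F)(F)F)cc3)CC2)c1C(=O)c1ccc(Cl)cc1`: 0%
- compound 3 `Nc1scc(CN2CCN(c3cccc(F)c3)CC2)c1C(=O)c1cccc(C(F)(F)F)c1`: 0%

Compound 2 stands level with compound 3 at the digits shown, and its gap to compound 1 is within the scatter; all three measured compounds sit at essentially no inhibition at the concentration tested.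

Compound 4 `Nc1scc(CN2CCN(c3cccc(F)c3F)CC2)c1C(=O)c1ccc(Cl)cc1` is the next compound, not yet measured. Its change from compound 2: 2,3-difluorophenyl in place of 4-(trifluoromethoxy)phenyl on an amine nitrogen in a ring

Among the compounds with values here, the one measured step that bears on this place, a swap of the group on the same ring nitrogen, is a number 1 percentage points lower from compound 1 to compound 2 (within the scatter), within the scatter. That step, and the matching value of compound 3 with yet another group on that nitrogen, show no movement in this assay across the three groups tried there. No step beyond the scatter is therefore expected for compound 4 in this assay.

Compound 4 is estimated at 1% in this assay, range -6% to 9%.

This estimate means an expected step of a number 1 percentage points higher from compound 2 to compound 4 (within the scatter), within the scatter.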

Compound 4, a percentage reported as inhibition, at one concentration (the size of the read-out at that concentration, not a potency): 0%
Estimate against measurement, compound 4: 1 percentage points above, and the stated range covers the measured number.
By their numbers in this assay, from the lowest: compounds 2, 3, 4 and 1 (each within the scatter of the next).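

In this assay, 2,3-difluorophenyl on the ring nitrogen in place of 4-(trifluoromethoxy)phenyl gives no change at the digits printed from compound 2 to compound 4 (within the scatter) and, set against 3,5-dichlorophenyl, gives a number 1 percentage points lower from compound 1 to compound 4 (within the scatter) on this same nitrogen. The position therefore also stays flat with a substituted phenyl of 8 heavy atoms and 0 hydrogen-bond acceptors, where the group it replaces has 11 heavy atoms and 1 hydrogen-bond acceptor. No measurement in hand speaks to the reason for this flat reading.

All groups shown on this nitrogen are halogen-bearing or fluoroalkoxy-bearing phenyl rings, so it remains open whether a phenyl carrying a hydroxyl or a carboxylic acid, or a benzyl group, would move the reading at all. With every value close to zero, these compounds also leave open which parts of the shared core matter for this receptor.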